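A few compounds are considered here, and "the series" means these few. Any claim that something is new, unique, unknown or untested is made for them only; others in the source may bear on it.

Compound 2 `COc1ccc(Oc2ccc([C@H]3S[C@@H](C)C(=O)Nc4c3c(C)nn4-c3ccccc3C)cc2)cc1` carries a 4-methoxyphenoxy group on the aromatic carbon para to the shared core. In an assay on isolated protein for agonist activity at Bile acid receptor (Homo sapiens), read by AlphaScreen, with a stated time of 30 min (on this read-out higher numbers stand for larger maximal responses and lower numbers for smaller maximal responses), compound 2 gives 70%. Among the compounds with values here, its only measured neighbour is compound 1 `Cc1ccccc1-n1nc(C)c2c1NC(=O)[C@H](C)S[C@@H]2c1ccc(-c2ccsc2)cc1`, which carries thiophen-3-yl at that carbon and in this assay gives 68%; the two values lie within the scatter of each other, as the step of a number 2 percentage points higher from compound 1 to compound 2 (within the scatter) shows.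

Compound 3 `Cc1ccccc1-n1nc(C)c2c1NC(=O)[C@H](C)S[C@@H]2c1ccc(-c2ccco2)cc1` is the next member of the series, not yet measured in this assay. furan-2-yl in place of 4-methoxyphenoxy on an aromatic carbon The furan-2-yl group that enters is a five-membered aromatic ring with one hetero atom, the same class of group as the thiophen-3-yl of compound 1. Within the data shown here, the one measured step that bears on this change, a number 2 percentage points higher from compound 1 to compound 2 (within the scatter), exchanged a five-membered heteroaromatic ring for 4-methoxyphenoxy and stayed within the scatter. The reverse kind of exchange is therefore expected to move the maximal response by no more than the scatter as well, an expected step of a number 2 percentage points lower from compound 2 to compound 3 (within the scatter). On that basis compound 3 is estimated to give 68% in this assay, with a range from 55% to 80%.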

Compound 3, largest response reached (reported as efficacy), in percent of the reference or control that the assay uses: 32%
Estimate against measurement, compound 3: 36 percentage points above; the measured number lies below the stated range.
By their numbers in this assay, from the lowest: compound 3; then compounds 1 and 2 (each within the scatter of the next).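

In this assay, the group on this aromatic carbon, para to a large group, proved not to be interchangeable: the exchange of 4-methoxyphenoxy for furan-2-yl gives a number 38 percentage points lower from compound 2 to compound 3 (beyond the scatter), a large step where the earlier exchange of thiophen-3-yl for 4-methoxyphenoxy had given only a number 2 percentage points higher from compound 1 to compound 2 (within the scatter) and had shown no sensitivity here. The comparison between the two five-membered rings is the more telling one, since the exchange of thiophen-3-yl for furan-2-yl gives a number 36 percentage points lower from compound 1 to compound 3 (beyond the scatter), so among these compounds belonging to the class of five-membered aromatic rings does not by itself decide the maximal response, and the much larger 4-methoxyphenoxy matches thiophen-3-yl while furan-2-yl stands apart. No measurement offered here explains why the response falls with furan-2-yl.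

Thiophen-3-yl and furan-2-yl differ both in the hetero atom and in the ring carbon that carries the bond, so these compounds cannot separate the two, and furan-3-yl or thiophen-2-yl at this carbon would be needed to do so. On these data alone, whether an unsubstituted phenyl, a phenoxy without the methoxy, or a saturated amine such as morpholine would keep the response also remains open.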